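The source may hold more compounds than are shown below. What is called first, only, known or untested is meant among the compounds shown, and "the series" means these compounds.

In a functional assay on the whole organism (Cricetulus griseus) with Cricetinae gen. sp. as the target (on this read-out lower numbers stand for an effect already at smaller amounts and higher numbers for an effect only at larger amounts of compound), three compounds have been measured so far.

Compound 1 `CCc1ccccc1-c1n[nH]c(-c2ccccc2)n1` gives 0.15 mg/kg.
Compound 2 `COc1ccc(-c2n[nH]c(-c3ccccc3)n2)c(C)c1` gives only a limit of the assay, > 10 mg/kg.
Compound 3 `COc1cccc(-c2nc(-c3ccc(OC)cc3C)n[nH]2)c1` gives 0.2 mg/kg.

The numbers for compound 1 and compound 3 lie within the usual scatter of each other, so nothing separates them. Compound 2 and compound 3 differ in one place, (methoxy in place of hydrogen on an aromatic carbon), and this change made an at least 50-fold lower number from compound 2 to compound 3 (1.69 log units; beyond the scatter). The true size of that step is not known, because the starting point is the limit of > 10 mg/kg in this assay, at which 1 of the 3 values shown sits. How the core of compound 1 differs from the core of compound 2 is not broken down here.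

Compound 4 `CCc1ccccc1-c1n[nH]c(-c2ccc(OC)cc2)n1` is not yet measured. It differs from compound 1 by methoxy in place of hydrogen on an aromatic carbon. This is the same kind of change as from compound 2 to compound 3, but not the same: there the methoxy sits meta to a large group, here para to a large group.

Compound 1 already gives a low number, and compound 3, which carries a methoxy para to a large group, gives 0.2 mg/kg, so for compound 4 a small step is expected, no change at the digits printed from compound 1 to compound 4 (within the scatter). Compound 4 is expected to give about 0.15 mg/kg, estimated between 0.05 mg/kg and 0.5 mg/kg.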

Compound 4, dose for half-maximal effect: 0.15 mg/kg
Compound 4: the middle estimate sits on the measured number at the digits printed; low and high end bracket the measured number.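

The methoxy in place of hydrogen on an aromatic carbon, here para to a large group, gives no change at the digits printed from compound 1 to compound 4 (within the scatter). The same kind of change therefore does not carry a fixed size from one core to another in this series, and a step seen on one core cannot simply be transferred to the other: the same change on two cores in this assay, an at least 50-fold lower number (1.69 log units; beyond the scatter) from compound 2 to compound 3 and no change at the digits printed (within the scatter) from compound 1 to compound 4, at least 50-fold (1.69 log units) apart, beyond the scatter of two such steps

This pair of steps does not give a general rule, nor does it show why the two steps differ, and the earlier one starts from a limit and not from a number, so its true size remains unknown: the limit of > 10 mg/kg in this assay, at which 1 of the 4 values shown sits.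

On the core of compound 1, the compounds shown offer only hydrogen and methoxy at this place on the ring. From the compounds shown here alone, it remains open how an amine, a carboxylic acid or a longer chain would behave there, and whether any of them would move the number beyond the scatter.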